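This account rests on a few compounds, and the source may have more. Where it says the series, first, only, none or still open, it means among the compounds named here.

Measured so far in an ADME assay on TZM cells (Homo sapiens) for cytotoxicity, read by CCK-8 assay, with a stated time of 2 days; a higher number here means that more compound is tolerated, a lower number that less compound is tolerated:
- compound 1 `COc1ccc(C(=O)Nc2ccc(CCS(=O)(=O)/C=C/c3ccc(OC(C)=O)c(OC(C)=O)c3)cc2)cc1`: 858000 nM
- compound 2 `CC(=O)Oc1ccc(/C=C/S(=O)(=O)CCc2ccc(NC(=O)c3cc(F)cc(F)c3)cc2)cc1OC(C)=O`: 225000 nM
- compound 3 `O=C(Nc1ccc(CCS(=O)(=O)/C=C/c2ccc(O)c(O)c2)cc1)c1ccccc1`: 238000 nM

Compound 3 lies within the scatter of compound 2, and compound 1 has a higher number than both, beyond the scatter. Compound 4 `O=C(Nc1ccc(CCS(=O)(=O)/C=C/c2ccc(O)c(O)c2)cc1)c1cc(F)cc(F)c1` carries 3,5-difluorophenyl in place of phenyl on a carbonyl carbon, otherwise matching compound 3: 3,5-difluorophenyl in place of phenyl on a carbonyl carbon.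

Among the measured compounds shown here, only one measured step bears on this change: a 3.8-fold lower number from compound 1 to compound 2 (0.58 log units; beyond the scatter). It brings in the same 3,5-difluorophenyl and is modest. However, the group it replaces is 4-methoxyphenyl rather than phenyl, and compound 1 and compound 2 differ from compound 3 elsewhere in the structure. For the measured compounds named here, no measured pair isolates the change from phenyl to 3,5-difluorophenyl, so the read-across is loose. A move in the same direction is expected, probably smaller and near the edge of the scatter.

The expected change is a 2.0-fold lower number from compound 3 to compound 4 (0.30 log units; within the scatter). For compound 4 the estimated value in this assay is 120000 nM, with an expected range of 50000 nM to 280000 nM.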

Compound 4, half-maximal cytotoxic concentration: 414000 nM
The estimate for compound 4 lay 3.5-fold (0.54 log units) below the measured number; measured number above the stated range.
By their numbers in this assay, from the lowest: compounds 2, 3 and 4 (each within the scatter of the next); then compound 1.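

In this assay, among the compounds shown here, phenyl and 3,5-difluorophenyl on a carbonyl carbon are compared directly for the first time, and the result is a 1.7-fold higher number from compound 3 to compound 4 (0.24 log units; within the scatter). With the core of compound 4, this exchange therefore gives no readable change, so the earlier 3.8-fold lower number from compound 1 to compound 2 (0.58 log units; beyond the scatter) cannot be taken as a general result of bringing in 3,5-difluorophenyl, since that step replaced 4-methoxyphenyl on a different core. Nothing available explains why the two steps differ.

The compounds shown do not separate the part played by the leaving 4-methoxyphenyl from the part played by the rest of the structure, so a pair with 4-methoxyphenyl on the core of compound 3 would be the most direct test. On these data alone, it also remains open whether anything on this carbonyl carbon moves the number beyond the scatter on that core, for instance a group carrying an amine or a carboxylic acid, or a longer chain in place of the aromatic ring.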